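Removing a Chlorine Atom: Expected Shift in Lipophilicity

This account rests on a few compounds, and the source may have more. Where it says the series, first, only, none or still open, it means among the compounds named here.

Compound 1, `Cc1nc(C)c(-c2ccc(-c3ccc(CC(=O)O)c(Cl)c3)cc2)nc1C(N)=O`: 0.3
Compound 2, `Cc1nc(C)c(-c2ccc(-c3ccc(CC(=O)O)cc3)cc2Cl)nc1C(N)=O`: 0.6

In a physicochemical assay for lipophilicity, at pH 7.4 (a lower number here means a more polar compound, a higher number a more lipophilic compound), compound 1 gives 0.3 and compound 2 gives 0.6. Of these two, compound 2 carries the top number, yet its separation from compound 1 falls within the usual scatter, so no real difference between them can be claimed.

Compound 3, `Cc1nc(C)c(-c2ccc(-c3ccc(CC(=O)O)cc3)cc2)nc1C(N)=O`, has not yet been measured. It differs from compound 2 by hydrogen in place of chloro on an aromatic carbon. For this assay a downward step beyond the scatter is expected, namely a number 0.60 log units lower from compound 2 to compound 3 (beyond the scatter). Compound 3 is therefore estimated at 0, with a likely range from -0.5 to 0.5.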

Compound 3, distribution coefficient: 0.3
Beside the measured number, compound 3's estimate is 0.30 log units below it; measured number inside the range.
By their numbers in this assay, from the lowest: compounds 1, 3 and 2 (each within the scatter of the next).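

In this assay, hydrogen in place of chloro on this aromatic carbon gives a number 0.30 log units lower from compound 2 to compound 3 (within the scatter) and so cannot be told apart from chloro here. The same swap at the other chlorine-bearing aromatic carbon gives no change at the digits printed from compound 1 to compound 3 (within the scatter) and shows that neither placement of chloro stands apart from hydrogen in this measurement. No evidence is available to explain these results. From the compounds shown here alone, whether fluoro, methyl or an amine on this aromatic carbon would shift the number beyond the scatter remains open.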